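This account rests on a few compounds, and the source may have more. Where it says the series, first, only, none or still open, it means among the compounds named here.

Working notes on the series in a functional assay on MGC-803 cells (Homo sapiens) for inhibition, read by CCK-8 assay, with a stated time of 48 h; a higher number here means a weaker inhibitor, a lower number a stronger inhibitor. Compound 1 (`COc1ccc(CN(C(=O)CSc2nc3ccccc3o2)c2cc(OC)c(OC)c(OC)c2)cc1`) gives 450 nM, and compound 2 (`COc1ccc(CN(C(=O)CSC(=S)N2CCOCC2)c2cc(OC)c(OC)c(OC)c2)cc1`) gives 2370 nM. Compound 3 (`COc1ccc(CN(C(=O)CSC(=S)N2CCCC2)c2cc(OC)c(OC)c(OC)c2)cc1`) gives > 20000 nM, which is a limit of the assay and not a number. It is the weakest of the three measured compounds.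

The next change leads to compound 4 (`CCN1CCN(CC(=O)N(Cc2ccc(OC)cc2)c2cc(OC)c(OC)c(OC)c2)CC1`): a group of 8 heavy atoms (6 carbon, 2 nitrogen; one six-membered non-aromatic ring with 2 hetero atoms) in place of a group of 8 heavy atoms (5 carbon, 1 nitrogen, 2 sulfur; one five-membered non-aromatic ring with 1 hetero atom), on a saturated chain carbon bound to a carbonyl carbon. Here 4-ethylpiperazin-1-yl enters on a saturated chain carbon bound to a carbonyl carbon. The measured steps bear on this only loosely, since each exchanges a group on a sulfur and compound 4 has no sulfur in that group. The closest guide is an at least 8.4-fold higher number from compound 2 to compound 3 (0.92 log units; beyond the scatter), at least modest in size, with the large at least 44-fold higher number from compound 1 to compound 3 (1.64 log units; beyond the scatter) showing how far the series can move. Compound 4 carries a six-membered non-aromatic ring with 2 hetero atoms, as does compound 2, whose value of 2370 nM points to a modest move toward a lower number.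

The expected change is an at least 5.0-fold lower number from compound 3 to compound 4 (0.69 log units; beyond the scatter), although a result at the limit remains possible. For compound 4 the estimated value is 4000 nM, with an expected range of 700 nM to 20000 nM.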

Compound 4, half-maximal inhibitory concentration: > 20000 nM
Compound 4 gave a limit, no number; the forecaster's own chance of this, stated with the estimate: 25%; at least 5.0-fold (0.69 log units) between middle value and limit.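

In this assay compound 4 gives > 20000 nM, which is a limit of the assay and not a number. With 4-ethylpiperazin-1-yl on a saturated chain carbon bound to a carbonyl carbon, and no sulfur in the group, the series shows an at least 8.4-fold higher number from compound 2 to compound 4 (0.92 log units; beyond the scatter) and an at least 44-fold higher number from compound 1 to compound 4 (1.64 log units; beyond the scatter), so a six-membered non-aromatic ring with 2 hetero atoms does not by itself keep the level of compound 2. The step between compound 3 and compound 4 cannot be read, because both sit at the same limit: the limit of > 20000 nM in this assay, at which 2 of the 4 values shown sit.

Open, as far as these compounds go, is whether the loss in compound 4 goes with the ethyl group, the ring or the missing sulfur, which an unsubstituted piperazin-1-yl or a morpholin-4-yl on the same chain carbon would help separate. Also open, from the compounds shown here alone, is how 4-ethylpiperazin-1-yl on a thiocarbonyl carbon would compare with the morpholin-4-yl of compound 2.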